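The source may hold more compounds than are shown below. What is called first, only, known or untested is meant among the compounds shown, and "the series" means these compounds.

Compound 1 `C=C(C)[C@@H]1CC=C(C)/C(=N/NC(=O)Nc2nnc(-c3ccc(Cl)cc3)o2)C1`: 100 mg/kg
Compound 2 `C=C(C)[C@@H]1CC=C(C)/C(=N/NC(=O)Nc2nnc(-c3ccc([N+](=O)[O-])cc3)o2)C1`: 100 mg/kg
Compound 3 `CC(C)=CC/C=C(/C)C/C=N/NC(=O)Nc1nnc(-c2ccc(Cl)cc2)o1`: 100 mg/kg

In a functional assay on the whole organism (strain Swiss albino) with Mus musculus as the target, with a stated time of 0.5 h (a higher number here means that more compound is needed for the effect, a lower number that less compound is needed), compound 1 gives 100 mg/kg, compound 2 gives 100 mg/kg and compound 3 gives 100 mg/kg. Compounds 1 and 2 differ by a single change, (nitro in place of chloro on an aromatic carbon), and the step of no change at the digits printed from compound 1 to compound 2 (within the scatter). Compound 3 carries a different core; the difference between the two cores is not broken down here. Compound 4 `CC(C)=CC/C=C(/C)C/C=N/NC(=O)Nc1nnc(-c2ccc([N+](=O)[O-])cc2)o1` is not yet measured. It stands to compound 3 as compound 2 stands to compound 1: nitro in place of chloro on an aromatic carbon, the same change at the same kind of place. Because no change at the digits printed from compound 1 to compound 2 (within the scatter), the step from compound 3 to compound 4 is expected to be no change at the digits printed from compound 3 to compound 4 (within the scatter). Compound 4 is therefore estimated at 100 mg/kg in this assay, with a range from 50 mg/kg to 200 mg/kg.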

Compound 4, minimum effective dose: 100 mg/kg
Estimate against measurement, compound 4: no gap at the digits printed, within the range that was stated.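

In this assay, nitro in place of chloro on the core of compound 3 gives no change at the digits printed from compound 3 to compound 4 (within the scatter), and this step agrees with the one on the core of compound 1: the same change on two cores in this assay, no change at the digits printed (within the scatter) from compound 1 to compound 2 and no change at the digits printed (within the scatter) from compound 3 to compound 4, 1.0-fold (0.00 log units) apart, within the scatter of two such steps. Across these two pairs, the change therefore carries from one core to the other with the same outcome. This does not show that it would carry to any further core, and two pairs give no reason for the agreement.

The compounds shown leave open how an amine, a carboxylic acid or a methoxy group would read in place of chloro on the aromatic carbon. They also leave open whether a different position on that ring would give the same reading.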